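This account rests on a few compounds, and the source may have more. Where it says the series, first, only, none or still open, it means among the compounds named here.

Series notes. In a functional assay on A2780 cells (Homo sapiens) for inhibition, read by MTT assay, with a stated time of 72 h (on this read-out lower numbers stand for stronger inhibition of growth and higher numbers for weaker inhibition of growth), compound 2 `COc1ccc(CNC(=O)/C(C#N)=C/c2cccc3ccccc23)cc1` gives 16000 nM, the lowest of the two numbers shown; the nearest is compound 3 `N#C/C(=C\c1ccc2ccccc2c1)C(=O)NCc1ccc(Cl)c(Cl)c1`, which gives 44000 nM, a gap beyond the scatter, though these two differ in more than one place. Compound 1 `COc1ccc(CNC(=O)/C(C#N)=C/c2ccc[nH]2)cc1` reaches only a limit of this assay, > 50000 nM, that is the limit of > 50000 nM in this assay, at which 1 of the 3 values shown sits. Compound 4 `N#C/C(=C\c1cccc2ccccc12)C(=O)NCc1ccc(Cl)c(Cl)c1` carries 3,4-dichlorophenyl in place of 4-methoxyphenyl on a saturated chain carbon bound to an amide-type nitrogen. Within the data shown here, no step between measured compounds covers this change alone, so no measured size is available for it. A modest move toward weaker inhibition is expected, since compound 3 gives 44000 nM with the same 3,4-dichlorophenyl on a saturated chain carbon bound to an amide-type nitrogen. For compound 4 the estimate is 25000 nM, range 8000 nM to 70000 nM, an expected step of a 1.6-fold higher number from compound 2 to compound 4 (0.19 log units; within the scatter).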

Compound 4, concentration for 50% growth inhibition: 7000 nM
Compound 4: middle estimate off by 3.6-fold (0.55 log units), on the high side, outside the stated range (below it).
By their numbers in this assay, from the lowest: compound 4; then compound 2; then compound 3. At a limit, above all of these: compound 1.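

In this assay, among these compounds, 3,4-dichlorophenyl in place of 4-methoxyphenyl on a saturated chain carbon bound to an amide-type nitrogen gives a 2.3-fold lower number from compound 2 to compound 4 (0.36 log units; beyond the scatter), the first measured step at this place. Compound 3, with the same 3,4-dichlorophenyl, gives 44000 nM, so that group alone does not set the level. Nothing on hand accounts for this step.

Open, on these data alone, is how 4-chlorophenyl or 3-chlorophenyl alone would compare at this place. Also open, as far as these compounds go, is how a pyridine ring or a phenyl bearing a carboxylic acid would fare here.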